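Aminomethyl in place of the urea side chain on compound 3

This account rests on a few compounds, and the source may have more. Where it says the series, first, only, none or still open, it means among the compounds named here.

Compound 3 `CCCC[S+]([O-])c1sc2nc(-c3nccs3)cc(-c3ccc(CNC(=O)NCC)cc3)c2c1N` stands second highest of three numbers in an assay for inhibition of 15-hydroxyprostaglandin dehydrogenase [NAD(+)] (Homo sapiens), read by fluorescence, with a stated time of 15 min, in the presence of a further agent that is not named here (a lower number here means a stronger inhibitor, a higher number a weaker inhibitor), where compound 3 gives 2.1 nM. Compound 2 `CCCC[S+]([O-])c1sc2nc(-c3nccs3)cc(-c3nccs3)c2c1N` gives 1.8 nM, and the two lie within the scatter of each other. For the measured compounds named here, compound 1 `CCCC[S+]([O-])c1sc2nc(-c3nccs3)cc(-c3ccc(C(=O)N(C)C)cc3)c2c1N` gives 5.9 nM; the step of a 2.8-fold lower number from compound 1 to compound 3 (0.45 log units; beyond the scatter) is the only measured change at this aromatic carbon. Compound 4 `CCCC[S+]([O-])c1sc2nc(-c3nccs3)cc(-c3ccc(CN)cc3)c2c1N` carries hydrogen in place of ethylcarbamoyl on an amine nitrogen. Going by the values given here, no measured step strips a group from this amine nitrogen, so the earlier step bears only indirectly: it shows the side chain on the aromatic carbon can be exchanged with a modest shift, and the thiazole of compound 2 points the same way. The expected step of a 1.7-fold higher number from compound 3 to compound 4 (0.22 log units; within the scatter) is therefore small, if anything toward a higher number. Compound 4 is estimated at 3.5 nM, with a range of 1.2 nM to 12 nM.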

Compound 4, half-maximal inhibitory concentration: 11.5 nM
The estimate for compound 4 lay 3.3-fold (0.52 log units) below the measured number, within the range that was stated.
By their numbers in this assay, from the lowest: compounds 2 and 3 (each within the scatter of the next); then compounds 1 and 4 (each within the scatter of the next).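

In this assay, hydrogen in place of ethylcarbamoyl on the amine nitrogen gives a 5.5-fold higher number from compound 3 to compound 4 (0.74 log units; beyond the scatter) and so shows that this end of the side chain matters more than the earlier exchanges suggested. The free aminomethyl compound also falls behind the 1,3-thiazol-2-yl compound, with a 6.4-fold higher number from compound 2 to compound 4 (0.81 log units; beyond the scatter) on that exchange, while aminomethyl and dimethylcarbamoyl stay together, with a 1.9-fold higher number from compound 1 to compound 4 (0.29 log units; within the scatter) on the aromatic carbon. No measurement here accounts for the change on losing ethylcarbamoyl.

Open, from the compounds shown here alone, is whether an acetyl group on this amine nitrogen keeps the number of compound 3. A longer chain on the urea is equally untested in these compounds.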